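Notes on the step from compound 2 to compound 4

A few compounds are considered here, and "the series" means these few. Any claim that something is new, unique, unknown or untested is made for them only; others in the source may bear on it.

Measured in a physicochemical assay for solubility, at pH 7.4; a lower number here means a less soluble compound, a higher number a more soluble compound:
compound 1 `Cc1cc(NC(=O)Nc2ccc(F)c(F)c2)c2ccccc2n1`: 500 nM
compound 2 `Cc1cc(NC(=O)Nc2cccc(F)c2)c2ccccc2n1`: 100 nM
compound 3 `COC(=O)c1cccc(NC(=O)Nc2cc(C)nc3ccccc23)c1`: 600 nM

Compound 2 stands lowest of the three in this assay, and compounds 1 and 3 both lie beyond the scatter above it. The next structure is compound 4 `Cc1cc(NC(=O)Nc2ncccc2C)c2ccccc2n1`, which carries 3-methylpyridin-2-yl in place of 3-fluorophenyl on an amide-type nitrogen.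

Among the measured compounds shown here, two measured steps bear on this change, though only indirectly: a 5.0-fold lower number from compound 1 to compound 2 (0.70 log units; beyond the scatter) and a 6.0-fold higher number from compound 2 to compound 3 (0.78 log units; beyond the scatter). Both are modest and beyond the scatter, and each exchanges one group on an aromatic carbon. For the measured compounds named here, neither replaces a whole ring, so the data hold no direct precedent for this change. The expectation rests on compound 2 sitting at the bottom of the measured values, with a 6.0-fold higher number from compound 2 to compound 3 (0.78 log units; beyond the scatter) as a guide to size. A modest upward step is expected, a 2.5-fold higher number from compound 2 to compound 4 (0.40 log units; beyond the scatter), although no change beyond the scatter remains possible. Compound 4 is estimated at 250 nM, with an expected range of 70 nM to 900 nM.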

Compound 4, solubility: 1300 nM
Compound 4: the middle estimate sits 5.2-fold (0.72 log units) below what was measured; the whole stated range lies below it.
By their numbers in this assay, from the lowest: compound 2; then compounds 1 and 3 (each within the scatter of the next); then compound 4.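

Among the compounds shown here, exchanging the whole ring on the amide-type nitrogen moves the number in this assay further than either exchange of a single group on an aromatic carbon, with a 13-fold higher number from compound 2 to compound 4 (1.11 log units; beyond the scatter) as the first large step. This position is therefore open to a change of ring as well as of substituent, and the direction of the step matches that of the move from compound 2 to compound 3. Nothing measured here accounts for the size of this step.

Since 3-methylpyridin-2-yl differs from 3-fluorophenyl in both the ring atoms and the substituent, compound 4 cannot assign the step to either difference alone. Going by these compounds, whether the ring nitrogen or the methyl carries it remains open, and a plain pyridin-2-yl or a 3-methylphenyl group on the same nitrogen would separate the two.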